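Phenylsulfanyl to 4-chlorophenoxy exchange on the shared core

The source may report more compounds than this note shows. Statements on the series, on what has been measured and on what is new or still open speak of the compounds shown alone.

Compound 1 `Nc1nc(-c2ccc(Cl)cc2)c(CC(=O)O)s1`: in an in vitro assay on HEK385-7 cells for displacement of a labelled ligand from prostaglandin D2 receptor 2 (Homo sapiens) (a higher number here means a weaker inhibitor, a lower number a stronger inhibitor), compound 1 gives > 100000 nM, which is a limit of the assay and not a number (the limit of > 100000 nM in this assay, at which 1 of the 3 values shown sits).
Compound 2 `O=C(O)Cc1sc(NCc2ccccc2)nc1-c1ccc(Cl)cc1`: in this assay compound 2 gives 440 nM.
Compound 3 `O=C(O)Cc1sc(CSc2ccccc2)nc1-c1ccc(Cl)cc1`: in this assay compound 3 gives 250 nM.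

Compound 3 holds the lowest of the two numbers, but compound 2 sits within the scatter of it, so no order between them is claimed. Both substitutions on the core of compound 1 give large steps: an at least 220-fold lower number from compound 1 to compound 2 (2.35 log units; beyond the scatter) and an at least 400-fold lower number from compound 1 to compound 3 (2.60 log units; beyond the scatter). The exchange of one such substituent for the other, a 1.8-fold lower number from compound 2 to compound 3 (0.25 log units; within the scatter), stays within the scatter.

Compound 4 `O=C(O)Cc1sc(COc2ccc(Cl)cc2)nc1-c1ccc(Cl)cc1` differs from compound 3 by 4-chlorophenoxy in place of phenylsulfanyl on a saturated chain carbon bound to an aromatic carbon. Among the measured compounds shown here, no measured step exchanges one substituent on this chain carbon for another of the same kind with a chlorine added; the only related comparison, a 1.8-fold lower number from compound 2 to compound 3 (0.25 log units; within the scatter), lies within the scatter. For compound 4 a step of a 1.3-fold lower number from compound 3 to compound 4 (0.10 log units; within the scatter) is therefore expected, none beyond the scatter. Compound 4 is estimated at 200 nM, with a range from 60 nM to 700 nM.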

Compound 4, half-maximal inhibitory concentration: 32 nM
Compound 4: the middle estimate sits 6.3-fold (0.80 log units) above what was measured; measured number outside the range, below it.
By their numbers in this assay, from the lowest: compound 4; then compounds 3 and 2 (each within the scatter of the next). At a limit, above all of these: compound 1.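

In this assay the saturated chain carbon bound to an aromatic carbon now shows a step beyond the scatter between two large substituents: 4-chlorophenoxy in place of phenylsulfanyl gives a 7.8-fold lower number from compound 3 to compound 4 (0.89 log units; beyond the scatter) and thus differs from the earlier exchange, a 1.8-fold lower number from compound 2 to compound 3 (0.25 log units; within the scatter) which stayed within the scatter. This single step replaces a sulfur with an oxygen and adds a chlorine, so it cannot be divided between the two changes. Nothing measured in the series accounts for the step.

Open, going by these compounds, is whether the step follows the oxygen or the chlorine: phenoxy and 4-chlorophenylsulfanyl on the same chain carbon would separate them. Also open, on these data alone, is how far the step extends to other groups on the phenoxy ring, such as 4-fluorophenoxy or 4-methoxyphenoxy.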